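A furanyl arm for a pyridinyl arm on the shared core

The source may hold more compounds than are shown below. What is called first, only, known or untested is meant among the compounds shown, and "the series" means these compounds.

Compound 1 `Oc1ccc(-c2cc(-c3cccnc3)nc(-c3ccccc3Cl)c2)cc1` carries a pyridin-3-yl group on its core, but in a functional assay on DU-145 cells (Homo sapiens) for cytotoxicity, read by CCK-8 assay and cell counting, with a stated time of 2 days (on this read-out higher numbers stand for weaker inhibition and lower numbers for stronger inhibition), compound 1 is reported as "not determined" (no result reported), so it stands with no number on this read-out. For the measured compounds named here, the only measured companion is compound 2 `Oc1ccc(-c2cc(-c3ccsc3)nc(-c3cccc(Cl)c3)c2)cc1`, which shares the core; in this assay compound 2 gives 6220 nM. Compound 3 `Oc1ccc(-c2cc(-c3ccco3)nc(-c3ccccc3Cl)c2)cc1` has not been measured. The change from compound 1 to compound 3 is furan-2-yl in place of pyridin-3-yl on an aromatic carbon. Going by the values given here, no step between measured compounds is available, so the size of this step in this assay cannot be read from the data; no step beyond the usual scatter is expected in either direction. Compound 3 is estimated at 7000 nM in this assay, with a range from 2500 nM to 20000 nM. Among the compounds with values here, this expectation rests on compound 2, whose 6220 nM is the sole number available.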

Compound 3, half-maximal inhibitory concentration: 5300 nM
Beside the measured number, compound 3's estimate is 1.3-fold (0.12 log units) above it; measured number inside the range.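

For the compounds shown here, no step from compound 1 to compound 3 can be read: compound 1 stands without a number in this assay on this read-out. The compounds shown leave open how furan-2-yl and pyridin-3-yl compare on the shared core. No evidence at hand bears on this result.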